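Moving the Halogen on the Outer Ring: Four Analogues

The compounds below may be only part of what the source reports. "The series", "measured", "known", "first", "only" and "open" are said of these compounds alone.

Compound 1 `O=C(NNc1cccc(Cl)c1)c1ccc(NS(=O)(=O)c2cnc(O)nc2O)cc1` gives 7290 nM
Compound 2 `O=C(NNc1ccccc1F)c1ccc(NS(=O)(=O)c2cnc(O)nc2O)cc1` gives 11700 nM
Compound 3 `O=C(NNc1cccc(Cl)c1)c1cccc(NS(=O)(=O)c2cnc(O)nc2O)c1` gives 6640 nM

All three values come from a functional assay on A549 cells (Homo sapiens) for antiproliferative activity, read by MTT assay, with a stated time of 24 h; a lower number here means a stronger inhibitor, a higher number a weaker inhibitor. Compound 1 and compound 3 are built from the same atoms joined differently; the difference between their two cores is not broken down here, and their values lie within the scatter of each other. Compound 2 comes from compound 1 by one change, (2-fluorophenyl in place of 3-chlorophenyl on an amine nitrogen), and that step reads a 1.6-fold higher number from compound 1 to compound 2 (0.21 log units; within the scatter). Compound 4 `O=C(NNc1ccccc1F)c1cccc(NS(=O)(=O)c2cnc(O)nc2O)c1` has not yet been measured in this assay. It comes from compound 3 by the same change, (2-fluorophenyl in place of 3-chlorophenyl on an amine nitrogen), made at the same place. Because the earlier step of a 1.6-fold higher number from compound 1 to compound 2 (0.21 log units; within the scatter) stayed within the scatter, a step of similar size is expected here, so compound 4 is estimated at a 1.5-fold higher number from compound 3 to compound 4 (0.18 log units; within the scatter). Among the measured compounds shown here, compound 3 at 6640 nM is the starting point for that expectation, and the only other example of the change, from compound 1 to compound 2, is the sole support for its size. Compound 4 is therefore expected to give about 10000 nM in this assay, likely between 5500 nM and 20000 nM.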

Compound 4, half-maximal inhibitory concentration: 11100 nM
Estimate against measurement, compound 4: 1.1-fold (0.05 log units) below, within the range that was stated.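

In this assay, placing 2-fluorophenyl instead of 3-chlorophenyl on the amine nitrogen gives a 1.7-fold higher number from compound 3 to compound 4 (0.22 log units; within the scatter), and this step matches the earlier one: the same change on two cores in this assay, a 1.6-fold higher number (0.21 log units; within the scatter) from compound 1 to compound 2 and a 1.7-fold higher number (0.22 log units; within the scatter) from compound 3 to compound 4, 1.0-fold (0.02 log units) apart, within the scatter of two such steps On these two cores, then, the change reads alike, and nothing here suggests that the choice between the core of compound 1 and the core of compound 3 alters its size. Still, each step lies within the scatter, so neither shows that the change really shifts the number, and two cores are too few to show how it would behave on any other core.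

The chlorine and fluorine also differ in where they sit on the ring, so the compounds shown cannot separate the identity of the halogen from its place. On these data alone, it also remains open how this assay would read with a more different group on that amine nitrogen, such as a phenyl ring carrying a carboxylic acid or an amine, or a longer chain.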